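This account rests on a few compounds, and the source may have more. Where it says the series, first, only, none or still open, it means among the compounds named here.

Measured so far:
- compound 1, `O=C(Nc1cc(C(F)(F)F)ccc1N1CCCC1)c1cccnc1Cl`: "not active" (no number reported)
- compound 2, `O=C(Nc1cc(C(F)(F)F)ccc1NC1CCCCC1)c1ccncc1`: 80900 nM
- compound 3, `O=C(Nc1cc(C(F)(F)F)ccc1N1CCCC1)c1ccncc1`: "not active" (no number reported)

Among the compounds with values here, in a functional assay on Jurkat cells (Homo sapiens) for cytotoxicity, read by MTT assay, with a stated time of 48 h (a higher number here means a weaker inhibitor, a lower number a stronger inhibitor), compound 2 gives 80900 nM, and this is the only number reported among the three measured compounds; compound 1 and compound 3 were each recorded without a number in this assay. Within the data shown here, compound 2 therefore stands alone as the one compound with a measured value, and it is a weak inhibitor by that value.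

Compound 4, `O=C(Nc1cc(C(F)(F)F)ccc1NC1CCCCC1)c1ccccc1`, differs from compound 2 in one place: phenyl in place of pyridin-4-yl on a carbonyl carbon. Among the measured compounds shown here, no step between two measured compounds describes this kind of change, so there is no basis within these data for expecting a large shift in either direction. The change is expected to leave the half-maximal inhibitory concentration roughly where compound 2 stands, with any step from compound 2 to compound 4 in this assay estimated at about a 1.0-fold lower number from compound 2 to compound 4 (0.00 log units; within the scatter), which is no more than the usual scatter. Compound 4 is accordingly expected to give about 80000 nM, with a likely range from 30000 nM to 250000 nM, and it could also be recorded without a number, as compounds 1 and 3 were.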

Compound 4, half-maximal inhibitory concentration: "not active" (no number reported)
Compound 4 has no reported number here, so the estimate cannot be set against anything.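

In this assay, within the data shown here, compound 4 is recorded without a number, so no step from compound 2 to it can be read. Nothing shown here offers an explanation for this result. Left open is how far phenyl in place of pyridin-4-yl shifts the half-maximal inhibitory concentration, with compound 2 the only compound carrying a number.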